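Swapping the halophenyl on a thioether-linked xanthine

The compounds below may be only part of what the source reports. "The series", "measured", "known", "first", "only" and "open" are said of these compounds alone.

Compound 1, `Cn1c(=O)c2c(nc(CCSc3cccc(Br)c3)n2C)n(C)c1=O`: 64100 nM in an in vitro assay on cells for inhibition of Amine oxidase [flavin-containing] B (Homo sapiens), read by coupled enzyme assay, with a stated time of 20 min; a higher number here means a weaker inhibitor, a lower number a stronger inhibitor
Compound 2, `COc1cccc(OCc2nc3c(c(=O)n(C)c(=O)n3C)n2C)c1`: 1960 nM in this assay

Of the two measured compounds, compound 1 gives the highest number, and compound 2 sits a good way below it, a gap beyond the usual scatter. The two share the same core but differ in several places at once, so their values say nothing about any single change. Compound 3, `Cn1c(=O)c2c(nc(CCSc3ccc(Cl)cc3)n2C)n(C)c1=O`, has not yet been measured. It differs from compound 1 in one place: 4-chlorophenyl in place of 3-bromophenyl on a sulfur. Going by the values given here, with no measured pair showing this change, the expected step of a 1.3-fold lower number from compound 1 to compound 3 (0.11 log units; within the scatter) is small, with no clear direction, or none beyond the scatter. Compound 3 is therefore estimated at about 50000 nM, with a likely range from 15000 nM to 200000 nM.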

Compound 3, half-maximal inhibitory concentration: 7790 nM
Compound 3: middle estimate off by 6.4-fold (0.81 log units), on the high side; the whole stated range lies above it.
By their numbers in this assay, from the lowest: compound 2; then compound 3; then compound 1.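

The group on the sulfur is not a silent position: in this assay, 4-chlorophenyl in place of 3-bromophenyl gives an 8.2-fold lower number from compound 1 to compound 3 (0.92 log units; beyond the scatter). Both groups have the same count of heavy atoms, and neither has a hydrogen-bond donor or acceptor, so these counts do not separate them, yet the values do. Nothing available here explains the step.

The swap changes the halogen and its place on the ring together, so the compounds shown cannot say which of the two matters; a 4-bromophenyl or a 3-chlorophenyl on the same sulfur would separate them. Also open, as far as these compounds go, is how the number responds to a different kind of group on this ring, such as an amine or a carboxylic acid.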